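Bromo for methyl on the shared core of compound 3

A few compounds are considered here, and "the series" means these few. Any claim that something is new, unique, unknown or untested is made for them only; others in the source may bear on it.

Measured compounds:
compound 1, `Cc1ccc2[nH]c(=O)c(CN(Cc3ccc(F)cc3)Cc3ccc(C(C)(C)C)cc3)cc2c1`, > 27000 nM
compound 2, `Cc1ccc2[nH]c(=O)c(CN(Cc3ccc(C(C)(C)C)cc3)C(C)c3ccc(OC(F)F)cc3)cc2c1`, > 5000 nM
compound 3, `Cc1ccc2[nH]c(=O)c(CN(Cc3ccc(C(C)(C)C)cc3)C(C)c3ccc(N(C)C)c(Cl)c3)cc2c1`, 9800 nM

In a toxicity assay on MDCK cells (Canis lupus familiaris) for cytotoxicity, read by crystal violet staining, with a stated time of 48 h (a lower number here means that less compound is tolerated, a higher number that more compound is tolerated), compound 1 reaches only a limit of the assay, > 27000 nM. Compound 2 likewise gives only a limit, > 5000 nM. Going by the values given here, compound 3 gives the single real number of the set, 9800 nM. Of the measured steps, an at least 2.7-fold lower number from compound 1 to compound 3 (0.44 log units; beyond the scatter) is readable, while a step that the two limits leave unreadable from compound 1 to compound 2 and a step that the limit leaves unreadable from compound 2 to compound 3 are not; all three change the group on the amine nitrogen and leave the core untouched. Compound 4 `CC(c1ccc(N(C)C)c(Cl)c1)N(Cc1ccc(C(C)(C)C)cc1)Cc1cc2cc(Br)ccc2[nH]c1=O` differs from compound 3 only on the shared core: bromo in place of methyl on an aromatic carbon. Among the compounds with values here, no measured step bears on that position, so no direction can be read from the data; the expectation is a step that stays within the scatter, no change at the digits printed from compound 3 to compound 4 (within the scatter). Compound 4 is therefore estimated at 9800 nM, between 4000 nM and 25000 nM.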

Compound 4, half-maximal cytotoxic concentration: 6100 nM
The estimate for compound 4 lay 1.6-fold (0.21 log units) above the measured number; measured number inside the range.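

Going by these compounds alone, the earlier compounds varied only the group on the amine nitrogen, so this is the first reading at this aromatic carbon of the shared core. In this assay, bromo in place of methyl gives a 1.6-fold lower number from compound 3 to compound 4 (0.21 log units; within the scatter), so compound 3 and compound 4 cannot be told apart here. Nothing shown offers a reason for this result.

As far as these compounds go, whether an amine, a carboxylic acid or a longer chain at this carbon would also stay within the scatter remains open. So does whether the same swap would behave alike with the amine substituents of compound 1 and compound 2.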